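A Ring Swap Without Precedent Among the Measured Pairs

The source may report more compounds than this note shows. Statements on the series, on what has been measured and on what is new or still open speak of the compounds shown alone.

Measured compounds:
compound 1, `N#Cc1ccc(-c2cnc3[nH]cc(-c4nnc(-c5ccc(F)cc5)o4)c(=O)c3c2)cc1`: 10.2%
compound 2, `CS(=O)(=O)c1ccc(-c2cnc3[nH]cc(-c4nnc(-c5ccc(F)cc5)o4)c(=O)c3c2)cc1`: 10.7%

In a functional assay on HCT-116 cells (Homo sapiens) for inhibition, read by MTT assay, with a stated time of 24 h, tested at 2.5 uM (a higher number here means more inhibition of growth at the concentration tested, a lower number less inhibition of growth), compound 1 gives 10.2% and compound 2 gives 10.7%. The step of a number 0.5 percentage points higher from compound 1 to compound 2 (within the scatter) lies within the scatter, so compound 2 and compound 1 cannot be told apart on these numbers. Compound 3 `CS(=O)(=O)c1ccc(-c2cnc3[nH]cc(-c4nnc(-c5cccnc5)o4)c(=O)c3c2)cc1` carries pyridin-3-yl in place of 4-fluorophenyl on an aromatic carbon. Among the compounds with values here, no measured step touches this change; the one step known concerns a different ring and was small. With no grounds for a shift beyond the scatter, compound 3 is expected to show a number 0.3 percentage points higher from compound 2 to compound 3 (within the scatter) in this assay, an estimate of 11% ranging from 0% to 28%.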

Compound 3, percent growth inhibition at one concentration: 4.32%
Compound 3: middle estimate off by 6.7 percentage points, on the high side; the range from low to high includes it.
By their numbers in this assay, from the lowest: compounds 3, 1 and 2 (each within the scatter of the next).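

In this assay, the first change measured at this position, on an aromatic carbon of the five-membered aromatic ring with 2 nitrogen and 1 oxygen, gives a number 6.4 percentage points lower from compound 2 to compound 3 (within the scatter). Exchanging 4-fluorophenyl for pyridin-3-yl, a ring with 1 hetero atom and 1 hydrogen-bond acceptor, therefore produces no shift that can be told from the scatter. No measurement available here bears on a cause. Left open is whether a larger change here, such as a phenyl ring carrying a carboxylic acid or an amine, would move the number beyond the scatter.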